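The compounds below may be only part of what the source reports. "The series", "measured", "known", "first", "only" and "open" are said of these compounds alone.

Series notes. Compound 3 `O=C(O)Cc1sc(C(c2ccccc2)c2ccc(F)c(F)c2)nc1-c1ccc(F)cc1` stands highest of the three measured compounds in an in vitro functional assay on HEK285-7 cells for antagonist activity at prostaglandin D2 receptor 2 (Homo sapiens), read by BRET and beta-arrestin recruitment; on this read-out higher numbers stand for larger maximal responses and lower numbers for smaller maximal responses: compound 3 gives 80%. Compound 1 `NS(=O)(=O)c1cccc(-c2nc(C(c3ccc(F)cc3)c3ccc(F)cc3)sc2CC(=O)O)c1` gives 55% in this assay, a number lower than that of compound 3 by more than the usual scatter. Compound 2 `O=C(O)Cc1sc(C2COc3ccccc3O2)nc1-c1ccc(Cl)cc1` gives 50% in this assay, lower still and again beyond the scatter. Compound 4 `O=C(O)Cc1sc(C(c2ccccc2)c2ccc(Cl)cc2)nc1-c1ccc(F)cc1` has not yet been measured; relative to compound 3 the change is 4-chlorophenyl in place of 3,4-difluorophenyl on a saturated chain carbon bound to two aromatic carbons. Within the data shown here, no measured pair shows this change on its own, so its size is not known from the data. The step from compound 3 to compound 4 in this assay is expected to be small, a slight fall or none beyond the scatter, a number 8 percentage points lower from compound 3 to compound 4 (within the scatter). For compound 4 the expected value in this assay is 72%, within a range of 52% to 90%.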

Compound 4, largest response reached (reported as efficacy), in percent of the reference or control that the assay uses: 80%
Estimate against measurement, compound 4: 8 percentage points below, and the stated range covers the measured number.
By their numbers in this assay, from the lowest: compounds 2 and 1 (each within the scatter of the next); then compounds 3 and 4 (each within the scatter of the next).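

At the saturated chain carbon bound to two aromatic carbons, 4-chlorophenyl in place of 3,4-difluorophenyl gives no change at the digits printed from compound 3 to compound 4 (within the scatter) in this assay. Among these compounds, this is the only single-place step so far, and it shows that this position accepts one chlorine in place of two fluorines on the phenyl ring with the maximal response staying within the scatter. Nothing at hand explains this result.

Going by these compounds, whether an amine or a carboxylic acid on that phenyl ring would give the same response remains open. So does whether this step holds when the other groups on the shared core differ.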